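A few compounds are considered here, and "the series" means these few. Any claim that something is new, unique, unknown or untested is made for them only; others in the source may bear on it.

Among the measured compounds, compound 3 `CN1CC(=O)Nc2cnc(Nc3ccc(Cl)cc3)nc21` carries the highest number in a functional assay on MDA-MB-468 cells (Homo sapiens) for cytotoxicity, read by MTT assay, with a stated time of 48 h (on this read-out lower numbers stand for stronger inhibition and higher numbers for weaker inhibition), where compound 3 gives 31300 nM. Compound 1 `O=C1CNc2nc(Nc3ccc(Cl)cc3)ncc2N1` gives 15000 nM in this assay. Compound 2 `CN1CC(=O)Nc2cnc(Nc3ccccc3)nc21` reaches only the limit of this assay, > 100000 nM. The two known steps are a 2.1-fold higher number from compound 1 to compound 3 (0.32 log units; beyond the scatter) and an at least 3.1-fold lower number from compound 2 to compound 3 (0.50 log units; beyond the scatter). Compound 4 `O=C1CN(Cc2ccccc2)c2nc(Nc3ccc(Cl)cc3)ncc2N1` differs from compound 3 by phenyl in place of hydrogen on a saturated chain carbon bound to a nitrogen on an aromatic ring in a ring. For the measured compounds named here, no measured step touches that position with a group larger than methyl, and the methyl step itself was the step of a 2.1-fold higher number from compound 1 to compound 3 (0.32 log units; beyond the scatter), so nothing here points firmly up or down. For compound 4 the expected step is a 1.3-fold lower number from compound 3 to compound 4 (0.10 log units; within the scatter), within the scatter. Compound 4 is estimated at 25000 nM, between 8000 nM and 80000 nM.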

Compound 4, half-maximal inhibitory concentration: > 100000 nM
Compound 4 gave a limit, no number (the forecaster's own chance of this, stated with the estimate: 15%); middle value at least 4.0-fold (0.60 log units) from the limit.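

Compound 4 gives a limit in this assay, not a number, so its steps have only one bound: the limit of > 100000 nM in this assay, at which 2 of the 4 values shown sit. The step from methyl to benzyl on this nitrogen is an at least 3.1-fold higher number from compound 3 to compound 4 (0.50 log units; beyond the scatter). Measured from the unsubstituted nitrogen, benzyl gives an at least 6.6-fold higher number from compound 1 to compound 4 (0.82 log units; beyond the scatter), whereas methyl gave a 2.1-fold higher number from compound 1 to compound 3 (0.32 log units; beyond the scatter), so the larger group moves the number further towards weaker inhibition. From the compounds shown here alone, it remains open whether an ethyl group or a longer chain of carbons would do the same without the phenyl ring. Going by these compounds, an amine or a carboxylic acid at the end of such a chain also remains untested here.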